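Hydroxy in place of carbamoyl on a hydroxamate chain

A few compounds are considered here, and "the series" means these few. Any claim that something is new, unique, unknown or untested is made for them only; others in the source may bear on it.

The study measured three compounds in a physicochemical assay for lipophilicity (on this read-out lower numbers stand for lower lipophilicity and higher numbers for higher lipophilicity), and now turns to a fourth. Compound 1 `O=C(NC1(C(=O)NO)CCN(Cc2ccccc2)CC1)c1ccc(C#Cc2ccccc2)cc1` reaches the upper limit of this assay, and its value of > 3 is a limit rather than a number. Compound 3 `O=C(NC1(C(=O)NO)CCSCC1)c1ccc(C#Cc2ccccc2)cc1` likewise sits at the limit, with > 3 being a limit and not a number. Compound 2 `NC(=O)C[C@H](NC(=O)c1ccc(C#Cc2ccccc2)cc1)C(=O)NO` is the only one of the three with a proper number: in this assay compound 2 gives 1. Thus compound 2 stands as the sole measured point below the limit, while the other two values shown are limits (the limit of > 3 in this assay, at which 2 of the 3 values shown sit).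

The step under consideration leads from compound 2 to compound 4 `O=C(N[C@@H](CO)C(=O)NO)c1ccc(C#Cc2ccccc2)cc1`, which has not yet been measured in this assay. The change is hydroxy in place of carbamoyl on a saturated chain carbon, two bonds along the chain from an amide-type nitrogen and a carbonyl carbon; cut one bond further out, it reads carbamoylmethyl to hydroxymethyl. Among the measured compounds shown here, no step between measured compounds is available that would show how such a change plays out in this assay, so the expectation rests on the change itself and on where compound 2 stands.

He expects a moderate rise in this assay, a step of a number 0.70 log units higher from compound 2 to compound 4 (beyond the scatter), larger than the usual scatter but well short of the limit. For compound 4 the estimate in this assay is 1.7, with a range from 1.1 to 2.3.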

Compound 4, distribution coefficient: 2
Estimate against measurement, compound 4: 0.30 log units below, within the range that was stated.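

Among the compounds shown here, until this result, no step in this assay had been available for any position, and this pair supplies the first: hydroxy in place of carbamoyl on a saturated chain carbon, two bonds along the chain from an amide-type nitrogen and a carbonyl carbon, amounts to a number 1.00 log units higher from compound 2 to compound 4 (beyond the scatter). The exchange replaces a group of 3 heavy atoms with one of 1 heavy atom, while the count of hydrogen-bond donors and acceptors is the same for both groups, so the step arises without any difference in that count. Compound 4 gives 2, a proper number. Compound 1 and compound 3 are the ones whose values are limits and not numbers: the limit of > 3 in this assay, at which 2 of the 4 values shown sit.

Going by these compounds, this is a single pair, so it remains open whether the same exchange would give a step of similar size on another core, or on a compound whose value is a limit. Also open, on these data alone, is how an amine or a carboxylic acid on the same saturated chain carbon, or a longer chain ending in hydroxy, would stand in this assay.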